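The compounds below may be only part of what the source reports. "The series", "measured", "known", "first", "only" and "open" are said of these compounds alone.

Compound 1 `CCCCCCCCn1cc(/C=C/C(=O)c2ccc(NC(=O)CN3CCN(C(=O)OC(C)(C)C)CC3)cc2)nn1` was tested in a functional assay on MCF7 cells (Homo sapiens) for inhibition, read by MTT assay (a lower number here means a stronger inhibitor, a higher number a weaker inhibitor), where compound 1 gives 98400 nM. Among the two compounds measured so far it stands at the higher end: its nearest neighbour, compound 2 `CCCCCCCCn1cc(/C=C/C(=O)c2ccc(NC(=O)CN3CCN(c4ccccc4OC)CC3)cc2)nn1`, gives 30000 nM in this assay, and the step of a 3.3-fold lower number from compound 1 to compound 2 (0.52 log units; beyond the scatter) carries the change of 2-methoxyphenyl in place of tert-butoxycarbonyl on an amine nitrogen in a ring.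

Compound 3 `CCCCCCCCCCn1cc(/C=C/C(=O)c2ccc(NC(=O)CN3CCN(C(=O)OC(C)(C)C)CC3)cc2)nn1` keeps the tert-butoxycarbonyl group of compound 1 and differs from it only in the chain on the aromatic nitrogen: ethyl in place of hydrogen on a saturated chain carbon, eight bonds along the chain from an aromatic nitrogen. Going by the values given here, the one measured step, from compound 1 to compound 2, touches the other end of the molecule and says nothing about lengthening this chain, so there is no step in the data that bears on the change from compound 1 to compound 3. Without such a reference, the expected step of a 1.4-fold lower number from compound 1 to compound 3 (0.15 log units; within the scatter) in this assay is small and may well lie within the scatter, in either direction. The estimate for compound 3 in this assay is therefore 70000 nM, with a range from 25000 nM to 200000 nM.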

Compound 3, half-maximal inhibitory concentration: 40000 nM
For compound 3 the middle estimate is 1.8-fold (0.24 log units) above the measured one; the range from low to high includes it.
By their numbers in this assay, from the lowest: compounds 2 and 3 (each within the scatter of the next); then compound 1.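

Lengthening the chain on the aromatic nitrogen, with ethyl in place of hydrogen on a saturated chain carbon, eight bonds along the chain from an aromatic nitrogen, gives a 2.5-fold lower number from compound 1 to compound 3 (0.39 log units; beyond the scatter) in this assay. The earlier compounds had shown a change only on the amine nitrogen in the ring, with a 3.3-fold lower number from compound 1 to compound 2 (0.52 log units; beyond the scatter), so this result adds a second place in the molecule where a single change moves the number beyond the scatter, here with the tert-butoxycarbonyl group kept. No measurement at hand explains this step.

The compounds shown leave open whether the same ethyl extension would lower the number when the 2-methoxyphenyl group stands on the ring nitrogen, and so whether the two changes add up, hold independently or cancel. They also leave open how the number would respond to a shorter chain, a still longer chain such as dodecyl, or a chain ending in an amine or a carboxylic acid, since one lengthening alone cannot define a trend at this position.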